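Amide replacement on a compound at the assay limit

This account rests on a few compounds, and the source may have more. Where it says the series, first, only, none or still open, it means among the compounds named here.

Two compounds of the series carry a shared core and differ in the amide and in the aryl group on the ring. Compound 1 `O=C(C1CCC(F)(F)CC1)N1CC(c2nc(-c3cccc(F)c3)no2)C1` gives 520 nM in an assay on HEK293 cells for positive allosteric modulation of metabotropic glutamate receptor 5 (Homo sapiens), read by FLIPR; a higher number here means that more compound is needed for the effect, a lower number that less compound is needed. Compound 2 `Cc1cccc(-c2noc(C3CN(C(=O)c4ccccc4F)C3)n2)c1` reaches only the limit of this assay, > 10000 nM, so no number stands for it; see (the limit of > 10000 nM in this assay, at which 1 of the 2 values shown sits). Nothing further is known about the 2-fluorophenyl amide in this series.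

Compound 3 `Cc1cccc(-c2noc(C3CN(C(=O)C4CCC(F)(F)CC4)C3)n2)c1` is not yet measured. It differs from compound 2 by 4,4-difluorocyclohexyl in place of 2-fluorophenyl on a carbonyl carbon. Within the data shown here, the 4,4-difluorocyclohexyl amide is the one present in compound 1, and since compound 1 gives 520 nM in this assay, compound 3 is expected to show 900 nM, within 250 nM to 5000 nM. The step expected from compound 2 to compound 3 is an at least 11-fold lower number from compound 2 to compound 3 (1.04 log units; beyond the scatter), a gain beyond the scatter, though its size cannot be fixed against a starting value that is itself only a limit.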

Compound 3, half-maximal effective concentration: 590 nM
Compound 3: the middle estimate sits 1.5-fold (0.18 log units) above what was measured; measured number inside the range.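

Working from this assay, 4,4-difluorocyclohexyl in place of 2-fluorophenyl on a carbonyl carbon moves the series from the assay limit to a readable value (an at least 16-fold lower number from compound 2 to compound 3 (1.22 log units; beyond the scatter)), so this amide position can decide whether a compound with the shared core gives a number at all. Compound 2 stands only as a limit of the assay, not as a number, and the full size of this step therefore cannot be fixed: the limit of > 10000 nM in this assay, at which 1 of the 3 values shown sits. Among these compounds, with the 4,4-difluorocyclohexyl amide held constant, methyl in place of fluoro on an aromatic carbon gives a 1.1-fold higher number from compound 1 to compound 3 (0.05 log units; within the scatter) and so separates nothing in this assay, leaving the amide as the only one of the two changes with a step beyond the scatter.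

Going by these compounds, it remains open whether the ring fluorines of the 4,4-difluorocyclohexyl group contribute, which a plain cyclohexyl amide would test, and whether a piperidine or a carboxylic acid on the same ring would be tolerated. The compounds shown also leave open whether the fluoro-bearing aryl group of compound 1 would lift the 2-fluorophenyl amide off the limit.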